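A Methyl Group on the Benzyl Ring of Compound 3

A few compounds are considered here, and "the series" means these few. Any claim that something is new, unique, unknown or untested is made for them only; others in the source may bear on it.

The account follows three measured compounds and one that awaits measurement in a functional assay on HeLa cells (Homo sapiens) for cytotoxicity, read by cell counting, with a stated time of 4 days; a lower number here means a stronger inhibitor, a higher number a weaker inhibitor. Compound 1 `Nc1cccc(/C=C2\SC(=O)N(Cc3ccc(F)cc3)C2=O)c1` gives 86000 nM in this assay. Compound 2 `Cc1ccc(CN2C(=O)S/C(=C\c3ccc(N)cc3)C2=O)cc1` reaches only a limit of the assay, > 250000 nM. Compound 3 `Nc1cccc(/C=C2\SC(=O)N(Cc3ccccc3)C2=O)c1` likewise returns only a limit, > 250000 nM. Thus compound 3 stands at the weak end of what the numbers show, and its value is not a number but a limit; the only step that touches it, an at least 2.9-fold higher number from compound 1 to compound 3 (0.46 log units; beyond the scatter), describes hydrogen in place of fluoro on an aromatic carbon and is at least modest. Compound 4 `Cc1ccc(CN2C(=O)S/C(=C\c3cccc(N)c3)C2=O)cc1` differs from compound 3 by methyl in place of hydrogen on an aromatic carbon. For the measured compounds named here, no measured step covers methyl in place of hydrogen, so the change carries no direct precedent, and compound 2, which also bears a methyl at that place, sits at the limit of > 250000 nM in this assay, at which 2 of the 3 values shown sit. The step from compound 3 is therefore expected to stay within the scatter, as a step that the limit leaves unreadable from compound 3 to compound 4. Compound 4 is expected at 300000 nM, within 120000 nM to 1000000 nM.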

Compound 4, half-maximal inhibitory concentration: 98000 nM
Beside the measured number, compound 4's estimate is 3.1-fold (0.49 log units) above it; the whole stated range lies above it.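

In this assay, the change from phenyl to 4-methylphenyl now has a readable direction, with an at least 2.5-fold lower number from compound 3 to compound 4 (0.40 log units; beyond the scatter), and the place of the amino group matters with the methyl in position: 3-aminophenyl in place of 4-aminophenyl gives an at least 2.5-fold lower number from compound 2 to compound 4 (0.40 log units; beyond the scatter). Methyl and fluoro at this place cannot be told apart, since the step reads a 1.1-fold higher number from compound 1 to compound 4 (0.06 log units; within the scatter). Compound 2 and compound 3 give only limits, so the two lower steps have a known direction but no exact size: the limit of > 250000 nM in this assay, at which 2 of the 4 values shown sit.

The compounds shown leave open whether a chloro or methoxy group at this place would behave like methyl and fluoro. They also leave open whether a hydroxyl group could stand in for the amino group on the other ring.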